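Moving a Methoxy Group in Two Related Series

A few compounds are considered here, and "the series" means these few. Any claim that something is new, unique, unknown or untested is made for them only; others in the source may bear on it.

Compound 1 `COc1ccccc1/C=C(/SCc1ccc(F)cc1)C(=O)c1ccc(Br)cc1`: 10000 nM
Compound 2 `COc1ccc(/C=C(/SCc2ccc(F)cc2)C(=O)c2ccc(Br)cc2)cc1`: 50000 nM
Compound 3 `COc1ccc(/C=C(/Sc2ccc(Br)cc2)C(=O)c2ccc(Cl)cc2)cc1`: 50000 nM

These three values come from a functional assay on DU-145 cells (Homo sapiens) for inhibition, read by trypan blue exclusion, with a stated time of 96 h; on this read-out lower numbers stand for stronger inhibition of growth and higher numbers for weaker inhibition of growth. Compound 1 and compound 2 share a core and differ in one place only: 2-methoxyphenyl in place of 4-methoxyphenyl on a double-bonded chain carbon bound to a double-bonded chain carbon. This change gave a 5.0-fold lower number from compound 2 to compound 1 (0.70 log units; beyond the scatter), so the methoxy group sitting closer to the chain went with stronger growth inhibition in this pair. Compound 3 stands level with compound 2 at the digits shown, and together they give the highest numbers of the three; the difference between the core of compound 2 and the core of compound 3 is not broken down here.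

Compound 4 `COc1ccccc1/C=C(/Sc1ccc(Br)cc1)C(=O)c1ccc(Cl)cc1` has not yet been measured. Among the measured compounds shown here, it differs from compound 3 by 2-methoxyphenyl in place of 4-methoxyphenyl on a double-bonded chain carbon bound to a double-bonded chain carbon, the same change as the one seen between compound 2 and compound 1. Because that change produced a 5.0-fold lower number from compound 2 to compound 1 (0.70 log units; beyond the scatter) in this assay, compound 4 is expected to show a step of about a 4.2-fold lower number from compound 3 to compound 4 (0.62 log units; beyond the scatter). The second core is different and untested for this change, so the range is kept wide. Compound 4 is estimated at 12000 nM in this assay, between 4000 nM and 40000 nM.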

Compound 4, concentration for 50% growth inhibition: 10000 nM
Compound 4: the middle estimate sits 1.2-fold (0.08 log units) above what was measured, and the stated range covers the measured number.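

In this assay, putting 2-methoxyphenyl in place of 4-methoxyphenyl on a double-bonded chain carbon bound to a double-bonded chain carbon gave a 5.0-fold lower number from compound 3 to compound 4 (0.70 log units; beyond the scatter), so stronger growth inhibition came with this change on the second core as well. Set side by side, the two steps match in size: the same change on two cores in this assay, a 5.0-fold lower number (0.70 log units; beyond the scatter) from compound 2 to compound 1 and a 5.0-fold lower number (0.70 log units; beyond the scatter) from compound 3 to compound 4, 1.0-fold (0.00 log units) apart, within the scatter of two such steps

In these two pairs, then, the change carried from one core to the other with its size intact, which makes it a consistent step within this small set, but two pairs in a single cell assay show neither why the change has this effect nor that it would hold on a third core.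

The compounds shown leave open whether a phenyl ring carrying a hydroxy group or a dimethylamino group in place of the methoxy group would give a similar step. They also leave open how the change would behave if the group on sulfur were replaced by a longer chain or by one ending in a carboxylic acid.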